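The compounds below may be only part of what the source reports. "The series", "measured", "known", "first", "only" and "open" are said of these compounds alone.

Working notes on the series. Compound 1 `CC(=O)N[C@@H](CSC/C=C(\C)CC/C=C(\C)CCC=C(C)C)C(=O)C=[N+]=[N-]` carries the longer chain and the diazo group on the carbonyl; in a functional assay on MOLT-3 cells (Homo sapiens) (a lower number here means a stronger inhibitor, a higher number a weaker inhibitor), compound 1 gives 32200 nM. Compound 2 `CC(=O)N[C@@H](CSC/C=C(\C)CCC=C(C)C)C(=O)C=[N+]=[N-]` is the shorter-chain analogue of compound 1. In this assay compound 2 reaches only a limit of the assay, > 100000 nM. Compound 3 `CC(=O)N[C@@H](CSC/C=C(\C)CC/C=C(\C)CCC=C(C)C)C(=O)CCl` keeps the longer chain and differs from compound 1 only at the carbonyl carbon; in this assay compound 3 gives 1400 nM, the lowest of the two numbers available.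

Two measured steps exist. The change at the carbonyl was large: a 23-fold lower number from compound 1 to compound 3 (1.36 log units; beyond the scatter). The chain shortening on the diazo series gave an at least 3.1-fold higher number from compound 1 to compound 2 (0.49 log units; beyond the scatter), a loss whose full size is hidden by the limit of > 100000 nM in this assay, at which 1 of the 3 values shown sits.

Compound 4 `CC(=O)N[C@@H](CSC/C=C(\C)CCC=C(C)C)C(=O)CCl` differs from compound 3 in one place: hydrogen in place of 3-methylbut-2-en-1-yl on a saturated chain carbon bound to a double-bonded chain carbon. This repeats the chain shortening seen between compound 1 and compound 2, now on the stronger carbonyl variant. Going by the values given here, the only precedent, an at least 3.1-fold higher number from compound 1 to compound 2 (0.49 log units; beyond the scatter), was an at least modest weakening, so a loss of at least that size is expected in this assay, and possibly more. The expected step is a 5.0-fold higher number from compound 3 to compound 4 (0.70 log units; beyond the scatter). Compound 4 is estimated at 7000 nM, within a range from 2500 nM to 30000 nM.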

Compound 4, half-maximal inhibitory concentration: > 100000 nM
Compound 4 was reported as a limit; the forecaster's own chance of this, stated with the estimate: 5%; middle value at least 14-fold (1.15 log units) from the limit.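

On the chlorine-bearing carbonyl variant, hydrogen in place of 3-methylbut-2-en-1-yl gives an at least 71-fold higher number from compound 3 to compound 4 (1.85 log units; beyond the scatter), a much larger minimum loss than the diazo pair could show. In this assay compound 4 gives > 100000 nM, which is a limit of the assay, so the advantage of the chlorine-bearing group seen with the longer chain does not yield a readable number once the chain is shortened. Among the four compounds, readable numbers occur only with 3-methylbut-2-en-1-yl present, and the chain change points the same way on both carbonyl variants, though its two sizes cannot be ranked: the same change on two cores in this assay, an at least 3.1-fold higher number (0.49 log units; beyond the scatter) from compound 1 to compound 2 and an at least 71-fold higher number (1.85 log units; beyond the scatter) from compound 3 to compound 4; the limit leaves it open whether they differ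

On these data alone, the steps between the two shorter-chain compounds cannot be read, so any effect of the carbonyl change on the shorter chain remains unknown: the limit of > 100000 nM in this assay, at which 2 of the 4 values shown sit. Also open is how the number would respond to a longer chain than that of compound 3, or to an amine or a carboxylic acid in place of the chlorine-bearing group on the carbonyl carbon.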